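This account rests on a few compounds, and the source may have more. Where it says the series, first, only, none or still open, it means among the compounds named here.

The measured compounds and their values in an ADME assay on HEK293 cells (Homo sapiens) for cytotoxicity, read by resazurin assay, with a stated time of 48 h; on this read-out lower numbers stand for higher toxicity in this test and higher numbers for lower toxicity in this test: compound 1 `O=S(=O)(Nc1ccc2oc(-c3ccccc3)nc2c1)c1cccc(C(F)(F)F)c1` gives a limit of the assay, > 100000 nM. Compound 2 `O=S(=O)(Nc1ccc2oc(-c3ccccc3)nc2c1)c1cccc(F)c1` gives 68000 nM. Compound 3 `O=S(=O)(Nc1ccc(-c2nc3ccccc3o2)cc1)c1ccc(F)cc1` gives a limit of the assay, > 100000 nM.

Compound 4 `O=S(=O)(Nc1ccc(-c2nc3ccccc3o2)cc1)c1ccc(C(F)(F)F)cc1` has not yet been measured in this assay. It differs from compound 3 by trifluoromethyl in place of fluoro on an aromatic carbon. The same kind of change is made from compound 2 to compound 1, (trifluoromethyl in place of fluoro on an aromatic carbon), but there the group enters meta to a large group, whereas in compound 4 it enters para to a large group. The measured change gave an at least 1.4-fold higher number from compound 2 to compound 1 (0.16 log units; that floor lies within the scatter); the size of that step is only a floor because of the limit of > 100000 nM in this assay, at which 2 of the 3 values shown sit. The difference between the core of compound 2 and the core of compound 3 is not broken down here.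

Compound 3 gives a limit of the assay, > 100000 nM. Resting on that and on the direction shown by an at least 1.4-fold higher number from compound 2 to compound 1 (0.16 log units; that floor lies within the scatter), compound 4 is expected to sit at the limit too, an expected step that the limit leaves unreadable from compound 3 to compound 4. Compound 4 is estimated at 150000 nM, between 70000 nM and 400000 nM.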

Compound 4, half-maximal cytotoxic concentration: 94000 nM
Compound 4: middle estimate off by 1.6-fold (0.20 log units), on the high side; the range from low to high includes it.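

In this assay, putting trifluoromethyl in place of fluoro on an aromatic carbon gives an at least 1.0-fold lower number from compound 3 to compound 4 (0.02 log units; that floor lies within the scatter). Neither this step nor the earlier one is more than a floor, and neither floor lies beyond the usual scatter, so the result gives no sign of a large shift on either core, but it does not prove that the change behaves alike on both: the same change on two cores in this assay, an at least 1.4-fold higher number (0.16 log units; that floor lies within the scatter) from compound 2 to compound 1 and an at least 1.0-fold lower number (0.02 log units; that floor lies within the scatter) from compound 3 to compound 4; the limit leaves it open whether they differ The true size of each step stays hidden because one compound in each pair is reported only as a limit, not as a number: the limit of > 100000 nM in this assay, at which 2 of the 4 values shown sit.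

The compounds shown leave open how the read-out would respond to other groups at the same place on the aromatic ring, such as an amine, a carboxylic acid or a longer chain. They also leave open whether trifluoromethyl in place of fluoro would give a fully readable step in a pair where both compounds give numbers rather than limits.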